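Changing one side group on a shared core

This account rests on a few compounds, and the source may have more. Where it says the series, first, only, none or still open, it means among the compounds named here.

Of the compounds shown here, three with a shared core have been tested in a functional assay on SW480 cells (Homo sapiens) for antiproliferative activity, read by MTT assay, with a stated time of 48 h; on this read-out lower numbers stand for stronger inhibition and higher numbers for weaker inhibition. Compound 1 `CC(C)=CCC[C@]1(C)/C=C/[C@@H](OC(=O)C=C(C)C)[C@](C)(O)/C=C/C(=O)/C(CN2CCCC2)=C\C1` gives 310 nM, compound 2 `COCOC/C1=C/C[C@](C)(CCC=C(C)C)/C=C/[C@@H](OC(=O)C=C(C)C)[C@](C)(O)/C=C/C1=O` gives 3710 nM, and compound 3 `CC(C)=CCC[C@]1(C)/C=C/[C@@H](OC(=O)C=C(C)C)[C@](C)(O)/C=C/C(=O)/C(COC(=O)c2ccc([N+](=O)[O-])cc2)=C\C1` gives 570 nM. Two steps fix where compound 3 stands: a 1.8-fold higher number from compound 1 to compound 3 (0.26 log units; within the scatter), and a 6.5-fold lower number from compound 2 to compound 3 (0.81 log units; beyond the scatter). Its number therefore cannot be told apart from that of compound 1, but it lies clearly under that of compound 2.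

Compound 4 `CC(C)=CCC[C@]1(C)/C=C/[C@@H](OC(=O)C=C(C)C)[C@](C)(O)/C=C/C(=O)/C(Cn2cc(CO)nn2)=C\C1` carries one change, on a saturated chain carbon bound to a double-bonded ring carbon: 4-(hydroxymethyl)-1H-1,2,3-triazol-1-yl in place of ((4-nitrophenyl)carbonyl)oxy on a saturated chain carbon bound to a double-bonded ring carbon. All three measured compounds differ at this same place, so all three steps bear on the change. The largest is a 12-fold higher number from compound 1 to compound 2 (1.08 log units; beyond the scatter), which shows that the group here can matter. The measured groups do not follow a simple trend, and no triazole has been tested, so the data give only a loose guide. The number for compound 2, at 3710 nM, leaves room for a rise, so a moderate upward move is the cautious expectation in this assay. The expected step is a 1.8-fold higher number from compound 3 to compound 4 (0.24 log units; within the scatter). Compound 4 is estimated at 1000 nM, with an expected range of 300 nM to 3500 nM.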

Compound 4, half-maximal inhibitory concentration: 2870 nM
For compound 4 the middle estimate is 2.9-fold (0.46 log units) below the measured one; the measured number falls inside the stated range.
By their numbers in this assay, from the lowest: compounds 1 and 3 (each within the scatter of the next); then compounds 4 and 2 (each within the scatter of the next).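

In this assay, the first triazole in the series moves away from the stronger pair: there is a 5.0-fold higher number from compound 3 to compound 4 (0.70 log units; beyond the scatter) and also a 9.3-fold higher number from compound 1 to compound 4 (0.97 log units; beyond the scatter) when 4-(hydroxymethyl)-1H-1,2,3-triazol-1-yl sits on the saturated chain carbon bound to a double-bonded ring carbon. Against methoxymethoxy at the same place there is a 1.3-fold lower number from compound 2 to compound 4 (0.11 log units; within the scatter) and so these two groups cannot be told apart, even though only the triazole carries an aromatic ring. The four compounds now fall into two pairs, compounds 1 and 3 with the lower numbers and compounds 2 and 4 with the higher ones, and an aromatic ring alone does not sort them, since compound 3 and compound 4 both carry one yet lie in different pairs.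

Still open, from the compounds shown here alone, is whether another amine, such as piperidine or morpholine, would match pyrrolidin-1-yl, and whether a triazole with a carboxylic acid or a longer chain in place of hydroxymethyl would shift the number in either direction. No measurement at hand explains why the groups divide in this way.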